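The compounds below may be only part of what the source reports. "The series", "measured", "known", "first", "only" and "open" are said of these compounds alone.

Three compounds have been measured in an in vitro functional assay on 1321-N1 cells for agonist activity at Free fatty acid receptor 1 (Homo sapiens), read by fluorescence; on this read-out higher numbers stand for an effect only at larger amounts of compound and lower numbers for an effect already at smaller amounts:

Compound 1 `C#Cc1cccc(C#Cc2ccc(CCC(=O)O)cc2)c1`: 155 nM
Compound 2 `O=C(O)CCc1ccc(C#Cc2cccc(CO)c2)cc1`: 891 nM
Compound 3 `Nc1cccc(C#Cc2ccc(CCC(=O)O)cc2)c1`: 1100 nM

Compound 3 carries the highest number of the three. Its gap to compound 2 is small, a 1.2-fold higher number from compound 2 to compound 3 (0.09 log units; within the scatter), so these two are indistinguishable on this read-out. Its gap to compound 1 is clear: a 7.1-fold higher number from compound 1 to compound 3 (0.85 log units; beyond the scatter), and the related exchange a 5.7-fold higher number from compound 1 to compound 2 (0.76 log units; beyond the scatter) points the same way, so the ethynyl group on compound 1 stands out against both the hydroxymethyl and the amino group.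

Compound 4 `O=C(O)CCc1ccc(C#Cc2cccc([N+](=O)[O-])c2)cc1` is not yet measured. It differs from compound 3 in one place: nitro in place of amino on an aromatic carbon. Among the measured compounds shown here, no measured step involves a nitro group, so the only guide is indirect. For the measured compounds named here, the step from compound 2 to compound 3, swapping one small polar group for another on the same aromatic carbon, stayed within the scatter, whereas the only change that moved the number beyond the scatter was the move away from the ethynyl group. A nitro group is a third small polar substituent at the same position, so a step within the scatter is expected here, with no clear direction, a 1.3-fold lower number from compound 3 to compound 4 (0.11 log units; within the scatter).

Compound 4 is therefore expected to give about 850 nM in this assay, within a range of 250 nM to 2800 nM.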

Compound 4, half-maximal effective concentration: 58.9 nM
The estimate for compound 4 lay 14-fold (1.16 log units) above the measured number; measured number below the stated range.
By their numbers in this assay, from the lowest: compound 4; then compound 1; then compounds 2 and 3 (each within the scatter of the next).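

In this assay, among the compounds shown here, this aromatic carbon proves far more sensitive to the choice of group than the earlier compounds could show: amino and hydroxymethyl had given numbers within the scatter of each other, yet the exchange for nitro produces a 19-fold lower number from compound 3 to compound 4 (1.27 log units; beyond the scatter) and a 15-fold lower number from compound 2 to compound 4 (1.18 log units; beyond the scatter). Nitro also goes past ethynyl, which had held the lowest number so far, with a 2.6-fold lower number from compound 1 to compound 4 (0.42 log units; beyond the scatter), so compound 4 now has the lowest number of the four, with its steps to all three others beyond the scatter. A change at this one position therefore spans the whole range seen in this small set, and the sequence from lowest number runs nitro, ethynyl, then amino and hydroxymethyl together.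

Nothing available explains why nitro stands apart from the other groups. From the compounds shown here alone, it also stays open whether the low number is special to nitro or is shared by other groups on this carbon, such as a nitrile or a trifluoromethyl group, and whether nitro would do the same on another carbon of this ring.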